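Phenoxyacetamide series: chloro to trifluoromethoxy at the aryl end

The source may report more compounds than this note shows. Statements on the series, on what has been measured and on what is new or still open speak of the compounds shown alone.

Measured so far:
compound 1 `Cc1nc(N2CCN(C3CCOCC3)CC2)nc2ccc(NC(=O)COc3ccc(Cl)cc3)cc12` – 115 nM
compound 2 `Cc1nc(N2CCN(S(C)(=O)=O)CC2)nc2ccc(NC(=O)COc3ccc(Cl)cc3)cc12` – > 10000 nM (a limit)
compound 3 `CCN1CCN(c2nc(C)c3cc(NC(=O)COc4ccc(Cl)cc4)ccc3n2)CC1` – "not determined" (no result reported)

Going by the values given here, in a functional assay on CHO-K1 cells for antagonist activity at melanin-concentrating hormone receptor 1 (Homo sapiens), read by inositol phosphate accumulation (on this read-out higher numbers stand for weaker inhibition and lower numbers for stronger inhibition), compound 1 gives 115 nM and is the only compound with a number in this set. Compound 2 returns only a limit of the assay, > 10000 nM, which is the limit of > 10000 nM in this assay, at which 1 of the 3 values shown sits. Compound 3 carries no result, "not determined" (no result reported).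

Among the compounds with values here, the single measured step, an at least 86-fold higher number from compound 1 to compound 2 (1.93 log units; beyond the scatter), changes the substituent on the amine nitrogen in the ring and leaves the aryl end untouched; it therefore says nothing about a change at the phenoxy ring.

Compound 4 `Cc1nc(N2CCN(C3CCOCC3)CC2)nc2ccc(NC(=O)COc3ccc(OC(F)(F)F)cc3)cc12` differs from compound 1 by trifluoromethoxy in place of chloro on an aromatic carbon. Within the data shown here, no measured step touches this position, so the expectation rests on compound 1 alone. The step of a 1.3-fold higher number from compound 1 to compound 4 (0.12 log units; within the scatter) is expected to stay within the scatter, with wide uncertainty in either direction. For compound 4 in this assay the estimate is 150 nM, expected to fall between 40 nM and 600 nM.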

Compound 4, half-maximal inhibitory concentration: 31 nM
For compound 4 the middle estimate is 4.8-fold (0.68 log units) above the measured one; measured number outside the range, below it.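

In this assay, going by these compounds alone, the aryl end responds to substitution: with the oxan-4-yl group held fixed, trifluoromethoxy in place of chloro on the aromatic carbon gives a 3.7-fold lower number from compound 1 to compound 4 (0.57 log units; beyond the scatter) as the first measured change at this position. Chloro is thus not the only group tolerated here, and a larger group with a hydrogen-bond acceptor gives the lower number. Nothing measured here bears on the cause of this step.

From the compounds shown here alone, with only these two groups compared on the phenoxy ring, it stays open whether the oxygen, the fluorines or the overall size of trifluoromethoxy goes with the lower number; trifluoromethyl, methoxy or nitrile in the same place would help separate these. Also open, going by these compounds, is whether the step carries over to other groups on the ring amine nitrogen, such as acetyl.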